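Changing the aryl group on the ring amine: compound 4

The compounds below may be only part of what the source reports. "The series", "measured", "known", "first", "only" and "open" are said of these compounds alone.

Measured so far in a functional assay on HL-60 cells (Homo sapiens) for inhibition, read by MTT assay, with a stated time of 72 h; on this read-out lower numbers stand for stronger inhibition and higher numbers for weaker inhibition:
compound 1 `Cc1nc(-c2ccccc2)c(C(=O)N2CCN(c3ccc(C(F)(F)F)cc3)CC2)o1` gives > 1000 nM
compound 2 `Cc1nc(-c2ccccc2)c(C(=O)N2CCN(c3ccccc3C(F)(F)F)CC2)o1` gives 120 nM
compound 3 `Cc1nc(-c2ccccc2)c(C(=O)N2CCN(c3cc(Cl)cc(Cl)c3)CC2)o1` gives 41.8 nM

The value of compound 1 is not a number but a limit, namely (the limit of > 1000 nM in this assay, at which 1 of the 3 values shown sits). Among the two real numbers, compound 3 stands lowest; its nearest neighbour is compound 2, with a 2.9-fold lower number from compound 2 to compound 3 (0.46 log units; beyond the scatter). The remaining steps also concern the aryl group on the amine nitrogen in a ring: an at least 8.3-fold lower number from compound 1 to compound 2 (0.92 log units; beyond the scatter) and an at least 23-fold lower number from compound 1 to compound 3 (1.37 log units; beyond the scatter). All three steps therefore lie beyond the scatter, and each of them arises from exchanging one aryl group for another at the same place.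

Compound 4 `Cc1nc(-c2ccccc2)c(C(=O)N2CCN(c3cccc(C#N)c3)CC2)o1` is the next member. It differs from compound 3 by 3-cyanophenyl in place of 3,5-dichlorophenyl on an amine nitrogen in a ring. This is again an exchange of the aryl group on the ring nitrogen, so the three measured steps bear on it; they show that such exchanges shift the number by modest to large amounts. Compound 3 holds the lowest number shown, so the more likely direction for compound 4 is upward, and a modest step is expected: a 3.6-fold higher number from compound 3 to compound 4 (0.55 log units; beyond the scatter). The number for compound 4 is estimated at 150 nM, within a range from 40 nM to 600 nM.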

Compound 4, half-maximal inhibitory concentration: 39.6 nM
Estimate against measurement, compound 4: 3.8-fold (0.58 log units) above; measured number outside the range, below it.
By their numbers in this assay, from the lowest: compounds 4 and 3 (each within the scatter of the next); then compound 2. At a limit, above all of these: compound 1.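

In this assay the exchange gives a 1.1-fold lower number from compound 3 to compound 4 (0.02 log units; within the scatter), so 3-cyanophenyl and 3,5-dichlorophenyl cannot be told apart on the amine nitrogen in the ring, and this position accepts a ring bearing a nitrile and one hydrogen-bond acceptor as readily as one bearing two chlorine atoms and no acceptor. The 3-cyanophenyl group also stands clear of 2-(trifluoromethyl)phenyl, with a 3.0-fold lower number from compound 2 to compound 4 (0.48 log units; beyond the scatter), so the lowest numbers in the series no longer rest on chlorine alone. Compound 1 has a limit and not a number, so the remaining comparison, an at least 25-fold lower number from compound 1 to compound 4 (1.40 log units; beyond the scatter), gives only a minimum size for the gap to 4-(trifluoromethyl)phenyl.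

Still open is how 3-cyanophenyl compares with plain phenyl, 3-(trifluoromethyl)phenyl or 4-cyanophenyl on the same nitrogen, since the compounds shown do not separate the identity of a substituent from its place on the aryl ring. Also open, going by these compounds, is whether an amine or a carboxylic acid in place of the nitrile would keep the number in the range shared by compound 3 and compound 4.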